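Notes on an amide-ring swap in the piperidine sulfonamide series

This account rests on a few compounds, and the source may have more. Where it says the series, first, only, none or still open, it means among the compounds named here.

Compound 1 `CCN(CC)S(=O)(=O)c1ccc(S(=O)(=O)N2CCC[C@@H](C(=O)N3CCS(=O)(=O)CC3)C2)cc1` is the weakest inhibitor of the three measured compounds. In a functional assay on BXPC-3 cells (Homo sapiens) for inhibition, read by MTT assay, with a stated time of 7 days (on this read-out higher numbers stand for weaker inhibition and lower numbers for stronger inhibition), compound 1 gives 4430 nM. Among the compounds with values here, compound 2 `CCN(CC)C(=O)c1ccc(S(=O)(=O)N2CCC[C@@H](C(=O)N3CCC(F)(F)CC3)C2)cc1` gives 240 nM and compound 3 `O=C([C@@H]1CCCN(S(=O)(=O)c2ccc(S(=O)(=O)N3CC[C@H](O)C3)cc2)C1)N1CCC(F)(F)CC1` gives 580 nM; the one single-point step among them, a 2.4-fold higher number from compound 2 to compound 3 (0.38 log units; beyond the scatter), concerns the substituent on the aromatic carbon and leaves the amide ring untouched.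

Compound 4 `CCN(CC)S(=O)(=O)c1ccc(S(=O)(=O)N2CCC[C@@H](C(=O)N3CC[C@@H](OC)C3)C2)cc1` keeps the diethylsulfamoyl part of compound 1 and changes the amide ring: 3-methoxypyrrolidin-1-yl in place of 1,1-dioxothiomorpholin-4-yl on a carbonyl carbon. Within the data shown here, no measured step changes this position alone. Compounds 2 and 3, which carry a different amide ring along with a different aromatic substituent, both sit well below compound 1, but since two places differ at once their numbers say nothing definite about the amide ring by itself.

Among the measured compounds shown here, with no direct precedent, the expectation for compound 4 rests on the weak showing of compound 1 at 4430 nM and the much lower numbers of compounds 2 and 3; a moderately lower number than compound 1 is expected, as a 3.0-fold lower number from compound 1 to compound 4 (0.47 log units; beyond the scatter), with wide uncertainty. Compound 4 is therefore estimated at 1500 nM, within a range of 400 nM to 5500 nM.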

Compound 4, half-maximal inhibitory concentration: 11500 nM
Compound 4: the middle estimate sits 7.7-fold (0.88 log units) below what was measured, and the stated range ends below it.
By their numbers in this assay, from the lowest: compound 2; then compound 3; then compound 1; then compound 4.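

Within the data shown here, this is the first step that changes the amide ring alone. With the diethylsulfamoyl part and the rest of the core held fixed, in this assay the swap gives a 2.6-fold higher number from compound 1 to compound 4 (0.41 log units; beyond the scatter), so the number does respond to the ring on this carbonyl carbon, and leaving 1,1-dioxothiomorpholin-4-yl does not by itself bring it down. The swap alters several things at once, from a six-membered to a five-membered ring, from two hydrogen-bond acceptors to one, with the sulfur lost and a defined stereocentre gained, and this single step cannot assign the shift to any one of them.

From the compounds shown here alone, whether a morpholin-4-yl or a 4-methylpiperazin-1-yl on the same carbonyl carbon would give a number on either side of that of compound 1 stays open, as does whether the same ring swap moves the number the same way with diethylcarbamoyl on the aromatic carbon. No measurement at hand bears on what lies behind this shift.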